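The source may hold more compounds than are shown below. What is called first, only, known or untested is meant among the compounds shown, and "the series" means these compounds.

Measured compounds in an assay on isolated protein for inhibition of Amine oxidase [flavin-containing] A (Homo sapiens), read by fluorescence, with a stated time of 15 min; on this read-out higher numbers stand for weaker inhibition and lower numbers for stronger inhibition:
compound 1 `COc1ccc(/C=C/c2cc(OC)cc(OC)c2/C=C/C(=O)c2cc3cc(Br)cc(OC)c3oc2=O)cc1`, compound 1 gives > 60000 nM.
compound 2 `COc1ccc(/C=C/c2cc(OC)cc(OC)c2/C=C/C(=O)c2cc3ccc(Cl)cc3oc2=O)cc1`, compound 2 gives > 60000 nM.
compound 3 `COc1ccc(/C=C/c2cc(OC)cc(OC)c2/C=C/C(=O)c2cc3cc(C)ccc3oc2=O)cc1`, compound 3 gives 30400 nM.

Where compound 2 stands: its value in this assay is a limit of the assay and not a number. The value of compound 1 is also only a limit. Compound 3 alone gives a number in this assay, and that number sits close to the limit (the limit of > 60000 nM in this assay, at which 2 of the 3 values shown sit).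

Compound 4 `COc1ccc(/C=C/c2cc(OC)cc(OC)c2/C=C/C(=O)c2cc3cc(Cl)ccc3oc2=O)cc1` is the next compound of the series. Relative to compound 2 the change is a group of 12 heavy atoms (9 carbon, 2 oxygen, 1 chlorine; one six-membered aromatic ring of carbon only, one six-membered aromatic ring with 1 hetero atom) in place of a group of 12 heavy atoms (9 carbon, 2 oxygen, 1 chlorine; one six-membered aromatic ring of carbon only, one six-membered aromatic ring with 1 hetero atom), on a carbonyl carbon. For the measured compounds named here, the only measured step at this carbonyl carbon is an at least 1.9-fold lower number from compound 2 to compound 3 (0.29 log units; that floor lies within the scatter), a step whose size cannot be resolved from the scatter since it starts from a limit. Going by the values given here, with compound 2 standing on a limit and the single comparable step not beyond scatter, no step beyond the scatter is expected from compound 2 to compound 4 in this assay, an at least 1.3-fold lower number from compound 2 to compound 4 (0.12 log units; that floor lies within the scatter). The estimate for compound 4 is therefore 45000 nM, expected between 15000 nM and 120000 nM, with a fair chance that only a limit is reported.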

Compound 4, half-maximal inhibitory concentration: > 60000 nM
Compound 4 ended at the assay's limit (the forecaster's own chance of this, stated with the estimate: 50%); at least 1.3-fold (0.12 log units) between middle value and limit.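

In this assay compound 4 gives > 60000 nM, which is a limit of the assay. The step between compound 2 and compound 4 cannot be read, so joining the same atoms differently on the carbonyl carbon shows no readable effect. For the compounds shown here, the one new readable comparison, chloro in place of methyl on an aromatic carbon, gives an at least 1.9-fold higher number from compound 3 to compound 4 (0.29 log units; that floor lies within the scatter), so the only number in the set is not resolved from its neighbour and the set stays crowded at the limit: the limit of > 60000 nM in this assay, at which 3 of the 4 values shown sit.

Whether any group on this part of the core can bring the value well clear of the limit stays open, since the compounds shown carry only chloro, bromo, methyl and methoxy groups there. From the compounds shown here alone, how an amine or a carboxylic acid on that aromatic carbon would read in this assay also remains open.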